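Swapping Chlorophenyl for Hydroxy-Methoxyphenyl: Expected Cell Tolerance

This account rests on a few compounds, and the source may have more. Where it says the series, first, only, none or still open, it means among the compounds named here.

Of the compounds shown here, three sharing one core have been tested for how much of them cells tolerate.
Compound 1 `COc1ccc(-c2nc3cnccn3c2Nc2cc(OC)c(OC)c(OC)c2)cc1O` gives 38000 nM in a functional assay on HEK-293T cells (Homo sapiens) for cytotoxicity, read by MTT assay; a lower number here means that less compound is tolerated, a higher number that more compound is tolerated.
Compound 2 `COc1cc(Nc2c(-c3ccc(Cl)cc3)nc3cnccn23)cc(OC)c1OC` gives 25000 nM in this assay.
Compound 3 `COc1ccc(Nc2c(-c3ccc(Cl)cc3)nc3cnccn23)cc1` gives 34000 nM in this assay.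

All three numbers sit within the usual scatter of one another, so none can be called better or worse tolerated than another. Compound 2 and compound 3 differ in more than one place, and the difference between their cores is not broken down here. Compound 4 `COc1ccc(Nc2c(-c3ccc(OC)c(O)c3)nc3cnccn23)cc1` has not yet been measured; it arises from compound 3 by one change, (3-hydroxy-4-methoxyphenyl in place of 4-chlorophenyl on an aromatic carbon). The same kind of change is already seen between two measured compounds, from compound 2 to compound 1, (3-hydroxy-4-methoxyphenyl in place of 4-chlorophenyl on an aromatic carbon), which gave a 1.5-fold higher number from compound 2 to compound 1 (0.18 log units; within the scatter). The two places are described almost alike; the ring atom next to the place bears a large group in compound 2 and a group of 9 heavy atoms in compound 3. Because the earlier step of a 1.5-fold higher number from compound 2 to compound 1 (0.18 log units; within the scatter) stayed within the scatter, a step of similar size is expected, a 1.3-fold higher number from compound 3 to compound 4 (0.12 log units; within the scatter). Compound 4 is therefore estimated at 45000 nM, most likely between 20000 nM and 100000 nM.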

Compound 4, concentration lethal to 50% of the cells: 38000 nM
The estimate for compound 4 lay 1.2-fold (0.07 log units) above the measured number; the range from low to high includes it.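

Exchanging 4-chlorophenyl for 3-hydroxy-4-methoxyphenyl gave a 1.1-fold higher number from compound 3 to compound 4 (0.05 log units; within the scatter) in this assay. Set beside the earlier case, the change reads the same on both cores: the same change on two cores in this assay, a 1.5-fold higher number (0.18 log units; within the scatter) from compound 2 to compound 1 and a 1.1-fold higher number (0.05 log units; within the scatter) from compound 3 to compound 4, 1.4-fold (0.13 log units) apart, within the scatter of two such steps. Within the data shown here, this shows that, on these two cores, the swap carried across without any step beyond the usual scatter, so the core made no visible difference to the outcome; it does not show that the swap has a real effect on how much compound the cells tolerate, nor that the same would hold on a third core, since only two pairs of compounds stand behind it.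

The compounds shown leave open whether any group at this place would move the number beyond the scatter, for example an amine, a carboxylic acid or a longer chain in place of the 3-hydroxy-4-methoxyphenyl. They also leave open how the hydroxy and the methoxy each count on their own, as the two enter together in both pairs.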